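The source may report more compounds than this note shows. Statements on the series, on what has been measured and on what is new or still open speak of the compounds shown alone.

The measured compounds and their values:

Compound 1 `Cc1ccc(S/C(=C/c2ccc(N(C)C)cc2)C(=O)c2ccc(Cl)cc2)cc1`. In a functional assay on DU-145 cells (Homo sapiens) for inhibition, read by trypan blue exclusion, with a stated time of 96 h (a lower number here means a stronger inhibitor of growth, a higher number a weaker inhibitor of growth), compound 1 gives only a limit of the assay, > 100000 nM.
Compound 2 `Cc1ccc(S/C(=C/c2sccc2C)C(=O)c2ccc(Cl)cc2)cc1`. In this assay compound 2 gives 50000 nM.
Compound 3 `CN(C)c1ccc(/C=C(/SCc2ccc(F)cc2)C(=O)c2ccc(Cl)cc2)cc1`. In this assay compound 3 gives 50000 nM.

All three compounds share the same core, and they differ from one another at two places. Compound 1 and compound 2 differ by 3-methylthiophen-2-yl in place of 4-(dimethylamino)phenyl on a double-bonded chain carbon bound to a double-bonded chain carbon. That change made the step of an at least 2.0-fold lower number from compound 1 to compound 2 (0.30 log units; that floor lies within the scatter), and the step can only be read as a floor because of the limit of > 100000 nM in this assay, at which 1 of the 3 values shown sits. Compound 1 and compound 3 differ by 4-fluorobenzyl in place of 4-methylphenyl on a sulfur, which gave the step of an at least 2.0-fold lower number from compound 1 to compound 3 (0.30 log units; that floor lies within the scatter). Compound 2 and compound 3 are level at the digits printed, and the two values lie within the scatter of each other.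

Compound 4 `Cc1ccsc1/C=C(/SCc1ccc(F)cc1)C(=O)c1ccc(Cl)cc1` has not yet been measured in this assay. It differs from compound 3 by 3-methylthiophen-2-yl in place of 4-(dimethylamino)phenyl on a double-bonded chain carbon bound to a double-bonded chain carbon. Among the measured compounds shown here, this is the same change as the one from compound 1 to compound 2, with the same place, made here on the core of compound 3 rather than on the core of compound 1. Compound 4 is expected to show the step of a 1.7-fold lower number from compound 3 to compound 4 (0.22 log units; within the scatter), a step of about the size of, or smaller than, the floor of the step from compound 1 to compound 2, because an at least 2.0-fold lower number from compound 1 to compound 2 (0.30 log units; that floor lies within the scatter) rests on a limit and its floor lies within the scatter. Compound 4 is therefore estimated to give 30000 nM in this assay, between 10000 nM and 100000 nM.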

Compound 4, concentration for 50% growth inhibition: 50000 nM
Beside the measured number, compound 4's estimate is 1.7-fold (0.22 log units) below it; the measured number falls inside the stated range.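

In this assay, putting 3-methylthiophen-2-yl in place of 4-(dimethylamino)phenyl on the core of compound 3 gives no change at the digits printed from compound 3 to compound 4 (within the scatter), and putting 4-fluorobenzyl in place of 4-methylphenyl on the sulfur of compound 2 gives no change at the digits printed from compound 2 to compound 4 (within the scatter). Set beside its earlier step, the 3-methylthiophen-2-yl change reads as follows: the same change on two cores in this assay, an at least 2.0-fold lower number (0.30 log units; that floor lies within the scatter) from compound 1 to compound 2 and no change at the digits printed (within the scatter) from compound 3 to compound 4; the limit leaves it open whether they differ. The 4-fluorobenzyl change reads the same way, and neither result shows that a change carries from one core to the other in equal size, or that it does not: the same change on two cores in this assay, an at least 2.0-fold lower number (0.30 log units; that floor lies within the scatter) from compound 1 to compound 3 and no change at the digits printed (within the scatter) from compound 2 to compound 4; the limit leaves it open whether they differ.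

What the compounds shown leave open is how either change would read on a core where both ends of the step give a plain number rather than a limit. Also open, going by these compounds, is how a longer chain on the sulfur, or a carboxylic acid in place of 3-methylthiophen-2-yl on the double-bonded chain carbon, would read in this assay.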